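Sulfonyl aryl variation on an inactive quinolone scaffold

The compounds below may be only part of what the source reports. "The series", "measured", "known", "first", "only" and "open" are said of these compounds alone.

Measured compounds:
Compound 1, `COc1ccc(-c2cc(=O)c3c(OC)cc(OC)cc3[nH]2)cc1`, in a functional assay on KOPN-8 cells (Homo sapiens) for antiproliferative activity, with a stated time of 72 h (on this read-out higher numbers stand for an effect only at larger amounts of compound and lower numbers for an effect already at smaller amounts), compound 1 gives > 31100 nM, a limit of the assay.
Compound 2, `COc1ccc(-c2cc(=O)c3c(OC)cc(OC)cc3n2S(=O)(=O)c2ccc(F)cc2)cc1`, in this assay compound 2 gives > 65500 nM, a limit of the assay.
Compound 3, `COc1ccc(-c2cc(=O)c3c(OC)cc(OC)cc3n2S(=O)(=O)c2cc(F)c(F)c(F)c2)cc1`, in this assay compound 3 gives > 65500 nM, a limit of the assay.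

Compound 3 stands among three values of which none is a number: it sits at the limit of > 65500 nM in this assay, at which 2 of the 3 values shown sit, and the remaining value sits at the limit of > 31100 nM in this assay, at which 1 of the 3 values shown sits. Compound 4, `COc1ccc(-c2cc(=O)c3c(OC)cc(OC)cc3n2S(=O)(=O)c2cccc(Br)c2)cc1`, differs from compound 3 in one place: 3-bromophenyl in place of 3,4,5-trifluorophenyl on a sulfonyl sulfur. The two measured steps that touch this series are a step that the two limits leave unreadable from compound 1 to compound 2 and a step that the two limits leave unreadable from compound 2 to compound 3, and neither is readable because the limit of > 31100 nM in this assay, at which 1 of the 3 values shown sits, and the limit of > 65500 nM in this assay, at which 2 of the 3 values shown sit, cap every value in the set. Going by the values given here, no measured step shows that a change of the aryl group on the sulfonyl sulfur moves this read-out out of the limit, and no step shows the opposite. Compound 4 is therefore expected to show no movement beyond the scatter, which is what a number no higher from compound 3 to compound 4 (the limit leaves the size open) is meant to express. The estimate for compound 4 in this assay is 65500 nM, with a range from 20000 nM to 130000 nM, most likely reported again as a limit.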

Compound 4, half-maximal effective concentration: > 58600 nM
Compound 4: a limit, no number; the forecaster's own chance of this, stated with the estimate: 85%; the middle value does not contradict the limit.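

In this assay compound 4 gives > 58600 nM, which is a limit of the assay. The steps to compound 4 from compound 1, compound 2 and compound 3 cannot be read, as all four values are limits. The compounds shown leave open whether any aryl group on the sulfonyl sulfur gives a measurable value in this assay.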